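Solubility across three hydroxamic acids sharing a phenylethynylbenzamide

The compounds below may be only part of what the source reports. "The series", "measured", "known", "first", "only" and "open" are said of these compounds alone.

Measured compounds:
- compound 1, `O=C(NC1(C(=O)NO)CCS(=O)(=O)CC1)c1ccc(C#Cc2ccccc2)cc1`: 2000 nM
- compound 2, `NC(=O)C[C@H](NC(=O)c1ccc(C#Cc2ccccc2)cc1)C(=O)NO`: 61000 nM
- compound 3, `O=C(NC1(C(=O)NO)CCN(Cc2ccccc2)CC1)c1ccc(C#Cc2ccccc2)cc1`: a limit only

In a physicochemical assay for solubility (on this read-out higher numbers stand for higher solubility and lower numbers for lower solubility), compound 2 gives 61000 nM. Of the two compounds that return a number, compound 2 stands highest; its nearest neighbour, compound 1, gives 2000 nM in this assay, and that gap lies well beyond the usual scatter. For compound 3 the reading is a limit rather than a number, < 1000 nM, which is the limit of < 1000 nM in this assay, at which 1 of the 3 values shown sits.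

Compound 4, `O=C(C[C@H](NC(=O)c1ccc(C#Cc2ccccc2)cc1)C(=O)NO)NCCCO`, has not yet been measured in this assay. It differs from compound 2 in a single place: 3-hydroxypropyl in place of hydrogen on an amide-type nitrogen. Within the data shown here, since no pair of measured compounds here differs in only one place, no measured step can anchor the outcome of this change.

The author expects compound 4 to sit close to compound 2, with a step of a 1.0-fold lower number from compound 2 to compound 4 (0.01 log units; within the scatter) that remains within the scatter. The estimate for compound 4 in this assay is therefore 60000 nM, expected to fall between 20000 nM and 180000 nM.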

Compound 4, solubility: 82000 nM
Compound 4: the middle estimate sits 1.4-fold (0.14 log units) below what was measured; the range from low to high includes it.
By their numbers in this assay, from the lowest: compound 1; then compounds 2 and 4 (each within the scatter of the next). At a limit, below all of these: compound 3.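

Among these compounds, compound 4 gives the series its only step at a single place, and in this assay it reads a 1.3-fold higher number from compound 2 to compound 4 (0.13 log units; within the scatter) on the amide-type nitrogen whose other neighbour is the carbonyl carbon. Among the compounds shown here, the amide hydrogen of compound 2 can therefore give way to 3-hydroxypropyl with a step that stays within the scatter, something the earlier compounds, which differ in more than one place, could not show. Nothing measured here speaks to why the two values stay level.

On these data alone, whether this holds for other groups on that nitrogen stays open: a plain propyl chain, a longer chain, a terminal amine or a carboxylic acid could each read differently in this assay and are not covered by this step. A single step also leaves open whether the hydroxyl end of the chain plays any part.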